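Methylsulfanyl in place of amino on compound 1

This account rests on a few compounds, and the source may have more. Where it says the series, first, only, none or still open, it means among the compounds named here.

Compound 1 `Cc1cc(NC(=O)Nc2ccccc2N)c2ccccc2n1` is one of two compounds with a reported result in an ADME assay on Raji cells (Homo sapiens) for cytotoxicity, with a stated time of 72 h; a lower number here means that less compound is needed, a higher number that more compound is needed for the effect. In this assay compound 1 gives > 25000 nM, which is a limit and not a number. Compound 2 `Cc1cc(NC(=O)Nc2cccc(F)c2)c2ccccc2n1` gives > 25000 nM, which is likewise a limit. Compound 1 therefore has no exact position on the scale, and the two results share the same limit (the limit of > 25000 nM in this assay, at which 2 of the 2 values shown sit). Within the data shown here, the only measured step, a step that the two limits leave unreadable from compound 1 to compound 2, places 3-fluorophenyl in place of 2-aminophenyl on an amide-type nitrogen, and its size cannot be read.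

Compound 3 `CSc1ccccc1NC(=O)Nc1cc(C)nc2ccccc12` keeps the core of compound 1 but has methylsulfanyl in place of amino on an aromatic carbon, ortho to a large group (methylsulfanyl in place of amino on an aromatic carbon). Among the measured compounds shown here, no measured step covers this exact replacement. The unreadable step that the two limits leave unreadable from compound 1 to compound 2 gives no size to carry over, so no change beyond the scatter is expected in either direction, and a further limit is the likeliest report. The expected step is a number no higher from compound 1 to compound 3 (the limit leaves the size open). In this assay the estimate for compound 3 is 25000 nM, with the value expected between 10000 nM and 50000 nM.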

Compound 3, half-maximal effective concentration: > 25000 nM
Compound 3: only a limit was reported; the forecaster's own chance of this, stated with the estimate: 80%; the middle value lies on the limit itself.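

No new step can be read: compound 1 and compound 3 both rest on the same limit, so the change from amino to methylsulfanyl has no readable size in this assay: the limit of > 25000 nM in this assay, at which 3 of the 3 values shown sit.

The compounds shown leave open whether any of them, compound 1, compound 2 or compound 3, has an effect at a measurable concentration in this assay.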